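The source may report more compounds than this note shows. Statements on the series, on what has been measured and on what is new or still open speak of the compounds shown alone.

Measured compounds:
- compound 1, `CCN(CC)S(=O)(=O)c1ccc(S(=O)(=O)N2CCC[C@@H](C(=O)NC)C2)cc1`: in a functional assay on MIA PaCa-2 cells (Homo sapiens) for inhibition, read by MTT assay, with a stated time of 7 days (a higher number here means a weaker inhibitor, a lower number a stronger inhibitor), compound 1 gives 8600 nM
- compound 2, `CCN(CC)S(=O)(=O)c1ccc(S(=O)(=O)N2CCC[C@@H](C(=O)NC3CN(S(C)(=O)=O)C3)C2)cc1`: in this assay compound 2 gives 2500 nM

Compound 2 holds the lowest number of the two measured; its nearest neighbour is compound 1, and the step of a 3.4-fold lower number from compound 1 to compound 2 (0.54 log units; beyond the scatter) lies beyond the scatter. Going by the values given here, the only change seen so far is the growth of the substituent on the amide-type nitrogen, from methyl to 1-(methylsulfonyl)azetidin-3-yl, which brought the number down modestly.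

Compound 3, `CCN(CC)S(=O)(=O)c1ccc(S(=O)(=O)N2CCC[C@@H](C(=O)N[C@H]3CCN(C(=O)OC(C)(C)C)C3)C2)cc1`, is the next member to be measured. The change from compound 2 is 1-(tert-butoxycarbonyl)pyrrolidin-3-yl in place of 1-(methylsulfonyl)azetidin-3-yl on an amide-type nitrogen. Among the compounds with values here, no measured pair tests this exact exchange; the single step of a 3.4-fold lower number from compound 1 to compound 2 (0.54 log units; beyond the scatter) shows only that a ring-bearing group on this nitrogen was tolerated and improved on methyl. Whether a larger five-membered ring with a tert-butoxycarbonyl cap behaves the same is open. A small step, within or just at the edge of the scatter, is expected in this assay, without a confident direction.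

Compound 3 is therefore estimated at 2000 nM, range 600 nM to 7000 nM, meaning an expected step of a 1.3-fold lower number from compound 2 to compound 3 (0.10 log units; within the scatter).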

Compound 3, half-maximal inhibitory concentration: 100 nM
Compound 3: middle estimate off by 20-fold (1.30 log units), on the high side; the whole stated range lies above it.
By their numbers in this assay, from the lowest: compound 3; then compound 2; then compound 1.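

In this assay, the substituent on this amide-type nitrogen matters far more than the first step indicated: 1-(tert-butoxycarbonyl)pyrrolidin-3-yl in place of 1-(methylsulfonyl)azetidin-3-yl gives a 25-fold lower number from compound 2 to compound 3 (1.40 log units; beyond the scatter), although both groups carry a non-aromatic ring and the same counted hydrogen-bond acceptors. Against the methyl amide, the same group gives an 86-fold lower number from compound 1 to compound 3 (1.93 log units; beyond the scatter), making compound 3 the strongest inhibitor of the three and showing that the presence of a ring alone does not set the number at this position. Nothing available explains the size of this step.

The exchange changes ring size, replaces the methylsulfonyl cap with tert-butoxycarbonyl and adds a defined stereocentre all at once, so the compounds shown do not assign the gain to any one of these changes. On these data alone, a 1-(methylsulfonyl)pyrrolidin-3-yl group, a 1-(tert-butoxycarbonyl)azetidin-3-yl group, the uncapped pyrrolidin-3-yl secondary amine and the opposite configuration at the pyrrolidine stereocentre remain open as the comparisons that would separate them.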